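Replacing the aromatic ring on the carbonyl carbon

This account rests on a few compounds, and the source may have more. Where it says the series, first, only, none or still open, it means among the compounds named here.

Among the compounds with values here, in an ADME assay on MT4 cells (Homo sapiens) for cytotoxicity, read by MTT assay (on this read-out lower numbers stand for higher toxicity in this test and higher numbers for lower toxicity in this test), compound 1 `O=C1c2ccccc2C(=O)N1CCOC(=S)N(C(=O)c1ccc([N+](=O)[O-])cc1Cl)c1ccc(Cl)cc1` gives 19000 nM and compound 2 `O=C1c2ccccc2C(=O)N1CCOC(=S)N(C(=O)c1cc([N+](=O)[O-])ccc1Cl)c1ccc(Cl)cc1` gives 45000 nM as the higher of the two numbers so far. Compound 3 `Cc1cc(C(=O)N(C(=S)OCCN2C(=O)c3ccccc3C2=O)c2ccc(Cl)cc2)c(C)o1` keeps the core of compound 2 but carries 2,5-dimethylfuran-3-yl in place of 2-chloro-5-nitrophenyl on a carbonyl carbon. Within the data shown here, only one measured step bears on this change: a 2.4-fold higher number from compound 1 to compound 2 (0.37 log units; beyond the scatter) is modest and swaps 2-chloro-4-nitrophenyl for 2-chloro-5-nitrophenyl, so the ring type stays the same. Among the measured compounds shown here, no measured compound carries a five-membered aromatic ring, so the data give no direction for this replacement, and no step beyond the scatter is expected in this assay. The expected step is a 1.3-fold lower number from compound 2 to compound 3 (0.11 log units; within the scatter) in this estimate. Compound 3 is estimated at 35000 nM with a range from 12000 nM to 100000 nM when measured.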

Compound 3, half-maximal cytotoxic concentration: 40000 nM
Compound 3: the middle estimate sits 1.1-fold (0.06 log units) below what was measured, and the stated range covers the measured number.
By their numbers in this assay, from the lowest: compound 1; then compounds 3 and 2 (each within the scatter of the next).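

On a carbonyl carbon whose other neighbour is the amide-type nitrogen, the ring type itself can now be changed: 2,5-dimethylfuran-3-yl, a five-membered aromatic ring with 1 hetero atom, replaces 2-chloro-5-nitrophenyl with a 1.1-fold lower number from compound 2 to compound 3 (0.05 log units; within the scatter) in this assay. Measured against 2-chloro-4-nitrophenyl, the same group gives a 2.1-fold higher number from compound 1 to compound 3 (0.32 log units; beyond the scatter), so among the three compounds only compound 1 stands apart, and a nitro group is not needed for the higher numbers seen with compound 2 and compound 3. Nothing available here accounts for these numbers.

The compounds shown leave open how an unsubstituted phenyl, a pyridine ring or a saturated cyclohexyl group would read on this carbonyl carbon. They also leave open whether an unsubstituted furan would read like 2,5-dimethylfuran-3-yl.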